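Methylsulfanyl in Place of Allylamino on the Shared Core

A few compounds are considered here, and "the series" means these few. Any claim that something is new, unique, unknown or untested is made for them only; others in the source may bear on it.

Compound 1 `C=CCNc1nc(N)c(C(=O)N=C(N)N)nc1Cl` gives 16% in an assay for inhibition of acid-sensing ion channel 3 (Homo sapiens), read by patch clamp, tested at 1 uM (on this read-out higher numbers stand for more inhibition at the one concentration tested (going by the name of the read-out) and lower numbers for less inhibition), the smallest of the three numbers recorded, though compound 3 sits within the scatter of it. Compound 2 `NC(N)=NC(=O)c1nc(Cl)c(NCc2ccc(Cl)cc2)nc1N` gives 46% and compound 3 `NC(N)=NC(=O)c1nc(Cl)c(NCc2ccccc2F)nc1N` gives 26%. The steps of a number 30 percentage points higher from compound 1 to compound 2 (beyond the scatter) and a number 10 percentage points higher from compound 1 to compound 3 (within the scatter) both come from placing an aryl group on the chain carbon, while a number 20 percentage points lower from compound 2 to compound 3 (beyond the scatter) contrasts the two aryl groups. Compound 4 `CSc1nc(N)c(C(=O)N=C(N)N)nc1Cl` differs from compound 1 in another way: methylsulfanyl in place of allylamino on an aromatic carbon. Going by the values given here, no measured step removes the allylamino group or introduces methylsulfanyl, so the three recorded steps give no direct guide, and the change is expected to leave the number within the scatter of compound 1, a number 1 percentage points lower from compound 1 to compound 4 (within the scatter). Compound 4 is therefore estimated at 15%, with a range from 0% to 35%.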

Compound 4, a percentage reported as inhibition, at one concentration (the size of the read-out at that concentration, not a potency): 12%
Beside the measured number, compound 4's estimate is 3 percentage points above it; the range from low to high includes it.
By their numbers in this assay, from the lowest: compounds 4, 1 and 3 (each within the scatter of the next, the first and the last beyond it); then compound 2.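

In this assay, methylsulfanyl in place of allylamino on this aromatic carbon gives a number 4 percentage points lower from compound 1 to compound 4 (within the scatter), so the earlier changes on the chain carbon are now joined by a change of the whole group, with no shift beyond the scatter. The hydrogen-bond donor and the double bond of allylamino both leave without a step beyond the scatter. Nothing shown explains this outcome. On these data alone, it remains open whether a 4-chlorobenzylsulfanyl group would give a step like a number 30 percentage points higher from compound 1 to compound 2 (beyond the scatter) on the amino-linked series. As far as these compounds go, a methoxy group or a plain amino group on this carbon also remains open.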